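A few compounds are considered here, and "the series" means these few. Any claim that something is new, unique, unknown or untested is made for them only; others in the source may bear on it.

Of the compounds shown here, three built on one shared core have been measured in an assay on isolated protein for inhibition of long-chain fatty acid transport protein 1 (Mus musculus); on this read-out higher numbers stand for weaker inhibition and lower numbers for stronger inhibition. Compound 1 `CCn1c(CNc2ccccc2)nnc1SCc1nc2cc(C(=O)C(C)C)ccc2o1` carries an isopropylcarbonyl on the aromatic carbon and gives 520 nM in this assay. Compound 3 `CCC(O)c1ccc2oc(CSc3nnc(CNc4ccccc4)n3CC)nc2c1`, with a 1-hydroxypropyl at that position, gives 3700 nM and stands highest of the two numbers shown, its nearest neighbour being compound 1 across the step of a 7.1-fold higher number from compound 1 to compound 3 (0.85 log units; beyond the scatter). Compound 2 `CCn1c(CNc2ccccc2)nnc1SCc1nc2cc(C)ccc2o1`, with a methyl there, reaches only a limit of the assay, > 10000 nM. The large step of an at least 19-fold higher number from compound 1 to compound 2 (1.28 log units; beyond the scatter) and the step of an at least 2.7-fold lower number from compound 2 to compound 3 (0.43 log units; beyond the scatter) place the methyl at the top, the 1-hydroxypropyl below it, and the isopropylcarbonyl lowest.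

Compound 4 `CCn1c(CNc2ccccc2)nnc1SCc1nc2cc(OC(F)(F)F)ccc2o1` has not yet been measured. It differs from compound 3 by trifluoromethoxy in place of 1-hydroxypropyl on an aromatic carbon. The entering group, like the methyl of compound 2, brings no hydrogen-bond donor and no carbonyl, whereas the 1-hydroxypropyl of compound 3 carries one donor. The three measured steps all lie beyond the scatter, so a step beyond the scatter is expected here too, and in the weakening direction: the step of a 1.6-fold higher number from compound 3 to compound 4 (0.21 log units; within the scatter) is the estimate, with a real chance that the assay reports only a limit. Compound 4 is therefore expected to give about 6000 nM in this assay, in a range from 2000 nM to 15000 nM.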

Compound 4, half-maximal inhibitory concentration: 91 nM
Compound 4: middle estimate off by 66-fold (1.82 log units), on the high side; measured number outside the range, below it.
By their numbers in this assay, from the lowest: compound 4; then compound 1; then compound 3. At a limit, above all of these: compound 2.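

In this assay, trifluoromethoxy gives the lowest number at this position, with a 5.7-fold lower number from compound 1 to compound 4 (0.76 log units; beyond the scatter) and a 41-fold lower number from compound 3 to compound 4 (1.61 log units; beyond the scatter) both beyond the scatter, so the isopropylcarbonyl of compound 1 no longer marks the best result here and a carbonyl is not required for the lowest number among these compounds. Nor does the absence of a hydrogen-bond donor go with weak inhibition as the methyl of compound 2 had allowed one to read it, for the two groups, neither with a donor, lie far apart in an at least 100-fold lower number from compound 2 to compound 4 (2.04 log units; beyond the scatter) at this single position. Compound 2 stands at a limit of the assay and not at a number: the limit of > 10000 nM in this assay, at which 1 of the 4 values shown sits.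

The compounds shown do not separate the contribution of the oxygen from that of the fluorine atoms in trifluoromethoxy, a question that methoxy and trifluoromethyl at this position would address. Going by these compounds, how an amine or a carboxylic acid would behave here also remains open, as does whether this order of groups would hold with anything other than the ethyl and the anilinomethyl of the shared core.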